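The source may hold more compounds than are shown below. What is called first, only, known or untested is meant among the compounds shown, and "the series" means these compounds.

Three compounds have been measured in an assay on membranes from brain for binding affinity to neutral cholesterol ester hydrolase 1 (Mus musculus), read by fluorescence, with stated times of 1 h and 30 min; on this read-out lower numbers stand for stronger inhibition and higher numbers for weaker inhibition:

compound 1, `O=C(N1CCCN(Cc2ccc(OCc3ccccc3)cc2)CC1)n1cccn1`, gives > 100000 nM, which is a limit of the assay and not a number.
compound 2, `N#Cc1cnn(C(=O)N2CCCN(Cc3ccc(OCc4ccccc4)cc3)CC2)c1`, gives > 100000 nM, again a limit of the assay.
compound 3, `O=C(N1CCN(C(c2ccc3ccccc3c2)c2ccc3ccccc3c2)CC1)n1cccn1`, gives > 100000 nM, also a limit of the assay.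

Compound 1 and compound 2 share one core and differ in a single place: cyano in place of hydrogen on an aromatic carbon. As far as these compounds go, the step that the two limits leave unreadable from compound 1 to compound 2 cannot be sized because both compounds sit at the limit of > 100000 nM in this assay, at which 3 of the 3 values shown sit, so it is unknown whether the cyano group helps, hurts or does nothing. Compound 3 is built on a different core; the difference between the two cores is not broken down here.

Compound 4, `N#Cc1cnn(C(=O)N2CCN(C(c3ccc4ccccc4c3)c3ccc4ccccc4c3)CC2)c1`, has not yet been measured. It stands to compound 3 exactly as compound 2 stands to compound 1: cyano in place of hydrogen on an aromatic carbon. The description of where the group enters is the same word for word in both pairs, so this is the same change. Nothing measured gives it a direction, and compound 3 rests at the limit of > 100000 nM in this assay, at which 3 of the 3 values shown sit, in this assay, so compound 4 is expected to remain at that limit as well. For the measured compounds named here, the step that the limit leaves unreadable from compound 3 to compound 4 is therefore expected to be essentially no step at all. For compound 4 the estimate is 150000 nM, with a range from 50000 nM to 500000 nM, and the result is expected to be reported only as a limit.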

Compound 4, half-maximal inhibitory concentration: > 100000 nM
Compound 4: no number, only a limit; the forecaster's own chance of this, stated with the estimate: 90%; the middle value lies beyond the limit too.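

In this assay compound 4 gives > 100000 nM, which is a limit of the assay and not a number. No step can be read from compound 3 to compound 4, since both rest at the same limit: the limit of > 100000 nM in this assay, at which 4 of the 4 values shown sit.

The compounds shown leave open whether cyano in place of hydrogen changes inhibition at all on either core, and what structure would give a true number.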